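This account rests on a few compounds, and the source may have more. Where it says the series, first, only, none or still open, it means among the compounds named here.

The compounds measured in a functional assay on HL-60 cells (Homo sapiens) for inhibition, read by MTT assay, with a stated time of 72 h (on this read-out higher numbers stand for weaker inhibition and lower numbers for stronger inhibition), are these:

- compound 1 `Cc1nc(-c2ccccc2)c(C(=O)N2CCN(c3cccc(Cl)c3)CC2)o1` gives 39.2 nM
- compound 2 `Cc1ccc(C)c(N2CCN(C(=O)c3oc(C)nc3-c3ccccc3)CC2)c1` gives 31.3 nM
- compound 3 `C=C(C)c1ccc(N2CCN(C(=O)c3oc(C)nc3-c3ccccc3)CC2)cc1` gives "not active" (no number reported)

Among the compounds with values here, compound 3 has no single number, so no step in size can be counted from it. The next compound, compound 4 `Cc1ccc(N2CCN(C(=O)c3oc(C)nc3-c3ccccc3)CC2)c(C)c1`, carries 2,4-dimethylphenyl in place of 4-(1-methylethenyl)phenyl on an amine nitrogen in a ring.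

Within the data shown here, only one measured step bears on this change. It is a 1.3-fold lower number from compound 1 to compound 2 (0.10 log units; within the scatter), which exchanges 3-chlorophenyl for 2,5-dimethylphenyl at that same nitrogen and stays within the scatter. Compound 2 thus shows that a dimethylphenyl group can give a measured value at this place (31.3 nM). Compound 4 is therefore expected to return a number in this assay and to sit within the scatter of the values of compound 1 and compound 2, not to repeat the result of compound 3. No size can be given for the step from compound 3, and a result without a number remains possible. With only these data the range is kept wide. The estimate for compound 4 is 40 nM, with an expected range from 12 nM to 140 nM (an estimate, not a measurement).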

Compound 4, half-maximal inhibitory concentration: 101 nM
For compound 4 the middle estimate is 2.5-fold (0.40 log units) below the measured one; low and high end bracket the measured number.
By their numbers in this assay, from the lowest: compounds 2 and 1 (each within the scatter of the next); then compound 4.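

Within this assay, the exchange of 2,5-dimethylphenyl for 2,4-dimethylphenyl on the amine nitrogen gives a 3.2-fold higher number from compound 2 to compound 4 (0.51 log units; beyond the scatter), so two dimethylphenyl groups that differ only in where their methyl groups sit do not give the same number at this position. The exchange of 3-chlorophenyl for 2,4-dimethylphenyl gives a 2.6-fold higher number from compound 1 to compound 4 (0.41 log units; beyond the scatter), so a dimethylphenyl group in place of 3-chlorophenyl does not always stay within the scatter, and the earlier pair alone did not show this; the steps from compound 3 cannot be read, as it has no number, although compound 4 does return one. Nothing in the data shown explains why these groups differ.

The compounds shown leave open whether a phenyl group bearing a single methyl, a methoxy group or a carboxylic acid would return a number in this assay and how it would compare with compound 4. They also leave open whether an isopropyl group in place of the 1-methylethenyl group of compound 3 would give a number at this nitrogen.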